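The compounds below may be only part of what the source reports. "The series", "measured", "known", "first", "only" and "open" are said of these compounds alone.

Compound 1 `Cc1nc(S(C)(=O)=O)ccc1Oc1ncnc(OC2CCN(C(=O)OC(C)C)CC2)c1F` stands as the lowest of the three numbers in a functional assay on isolated protein for inhibition of Glucose-dependent insulinotropic receptor (Rattus norvegicus), read by HTRF and cAMP accumulation (a higher number here means that more compound is needed for the effect, a lower number that less compound is needed), at 142 nM. Compound 3 `Cc1nc(S(C)(=O)=O)ccc1Oc1ncnc(OC2CCN(C(=O)OC3(C(F)(F)F)COC3)CC2)c1F` gives 342 nM and compound 2 `Cc1nc(S(C)(=O)=O)ccc1Oc1ncnc(OC2CCN(C(=O)OC3COC3)CC2)c1F` gives 2500 nM; the steps of a 2.4-fold higher number from compound 1 to compound 3 (0.38 log units; beyond the scatter) and an 18-fold higher number from compound 1 to compound 2 (1.25 log units; beyond the scatter) both alter the isopropyl side of the carbamate. Compound 4 `Cc1nc(S(C)(=O)=O)ccc1Oc1ncnc(OC2CCN(C(=S)OC(C)C)CC2)c1F` differs from compound 1 elsewhere: a group of 6 heavy atoms (4 carbon, 1 oxygen, 1 sulfur; no ring) in place of a group of 6 heavy atoms (4 carbon, 2 oxygen; no ring), on an amine nitrogen in a ring. Going by the values given here, no measured step touches the carbonyl oxygen itself, so the two steps from compound 1 give no direct guide, and the change is read as small. A step of a 1.8-fold higher number from compound 1 to compound 4 (0.25 log units; within the scatter) is expected, at or just beyond the scatter, toward a higher number. Compound 4 is estimated at 250 nM, with a range from 80 nM to 800 nM in this assay.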

Compound 4, half-maximal effective concentration: 1050 nM
For compound 4 the middle estimate is 4.2-fold (0.62 log units) below the measured one, outside the stated range (above it).
By their numbers in this assay, from the lowest: compound 1; then compound 3; then compound 4; then compound 2.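

In this assay the carbamate side is sensitive at the carbonyl oxygen as well as at the isopropyl group, with sulfur in that place giving a 7.4-fold higher number from compound 1 to compound 4 (0.87 log units; beyond the scatter) while the isopropyl group stays unchanged. The same group on the amine nitrogen sits in the middle of the set, with a 3.1-fold higher number from compound 3 to compound 4 (0.49 log units; beyond the scatter) on one side and a 2.4-fold lower number from compound 2 to compound 4 (0.38 log units; beyond the scatter) on the other. No evidence on the origin of this step is available.

From the compounds shown here alone, whether sulfur has a similar effect alongside oxetan-3-yl or 3-(trifluoromethyl)oxetan-3-yl remains open. So does the outcome with a urea or an amide on this nitrogen.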